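Acyl piperazine series: solubility step to a cyclopentyl amide

The compounds below may be only part of what the source reports. "The series", "measured", "known", "first", "only" and "open" are said of these compounds alone.

Compound 3 `CCC(C)C(=O)N1CCN(c2nc(=O)c3cc(C(F)(F)F)cc([N+](=O)[O-])c3s2)CC1` gives 104 ug/mL in a physicochemical assay for solubility, read by HPLC (a lower number here means a less soluble compound, a higher number a more soluble compound), the highest of the three numbers in hand. Compound 2 `CCCCC(=O)N1CCN(c2nc(=O)c3cc(C(F)(F)F)cc([N+](=O)[O-])c3s2)CC1` gives 42.5 ug/mL. The gap between them is a 2.4-fold higher number from compound 2 to compound 3 (0.39 log units; beyond the scatter). Compound 1 `CCCC(=O)N1CCN(c2nc(=O)c3cc(C(F)(F)F)cc([N+](=O)[O-])c3s2)CC1` gives 2.46 ug/mL; the gap from it to the best compound is a 42-fold higher number from compound 1 to compound 3 (1.63 log units; beyond the scatter), and between the two unbranched chains a 17-fold higher number from compound 1 to compound 2 (1.24 log units; beyond the scatter). Compound 4 `O=C(C1CCCC1)N1CCN(c2nc(=O)c3cc(C(F)(F)F)cc([N+](=O)[O-])c3s2)CC1` carries cyclopentyl in place of sec-butyl on a carbonyl carbon. Going by the values given here, the step that bears most on it is a 2.4-fold higher number from compound 2 to compound 3 (0.39 log units; beyond the scatter), a modest one on a carbonyl carbon; no measured step involves a ring, so the branched and ring-bearing acyl groups are taken to read alike. A step of a 1.5-fold lower number from compound 3 to compound 4 (0.17 log units; within the scatter) is expected, within the scatter. Compound 4 is estimated at 70 ug/mL, range 20 ug/mL to 220 ug/mL.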

Compound 4, solubility: 5.34 ug/mL
For compound 4 the middle estimate is 13-fold (1.12 log units) above the measured one, outside the stated range (below it).
By their numbers in this assay, from the lowest: compound 1; then compound 4; then compound 2; then compound 3.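

On the carbonyl carbon, cyclopentyl does not read like the branched sec-butyl group in this assay: the change gives a 19-fold lower number from compound 3 to compound 4 (1.29 log units; beyond the scatter), so a ring and an open branched chain cannot be treated as alike here. The ring also falls short of the longer open chain, with an 8.0-fold lower number from compound 2 to compound 4 (0.90 log units; beyond the scatter), yet it does not fall to the level of the shortest chain, with a 2.2-fold higher number from compound 1 to compound 4 (0.34 log units; beyond the scatter). Nothing at hand accounts for this drop.

From the compounds shown here alone, whether cyclobutyl or cyclohexyl would track compound 4, and whether isopropyl or tert-butyl would track compound 3, stays open. So does the outcome for a ring carrying an ether oxygen, such as tetrahydrofuranyl, on this carbonyl carbon.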